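Swapping an Aryl Group in a Set That Shows No Activity

The compounds below may be only part of what the source reports. "The series", "measured", "known", "first", "only" and "open" are said of these compounds alone.

Compound 3 `COc1ccc(-n2nncc2CN2C(=O)C3(C(C#N)=C(N)Oc4c(N)cc5nc6ccccc6nc5c43)c3ccccc32)cc1` was tested in a functional assay on MCF7 cells (Homo sapiens) for antiproliferative activity, read by MTT assay, with a stated time of 48 h; a higher number here means a weaker inhibitor, a lower number a stronger inhibitor. In this assay compound 3 gives > 50000 nM, which is a limit of the assay and not a measured number. Two close relatives carry the same reading. Compound 1 `N#CC1=C(N)Oc2c(c3nc4ccccc4nc3c3ccccc23)C12C(=O)N(Cc1cnnn1-c1ccccc1Br)c1ccccc12` gives > 50000 nM in this assay, again a limit. Compound 2 `COc1ccc(-n2nncc2CN2C(=O)C3(C(C#N)=C(N)Oc4c3c3nc5ccccc5nc3c3ccccc43)c3ccccc32)cc1` gives > 50000 nM in this assay, also a limit. Going by the values given here, the one step between measured compounds, from compound 1 to compound 2, is a step that the two limits leave unreadable from compound 1 to compound 2, so its size cannot be read. Everything known so far is summed up by the limit of > 50000 nM in this assay, at which 3 of the 3 values shown sit.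

Compound 4 `N#CC1=C(N)Oc2c(N)cc3nc4ccccc4nc3c2C12C(=O)N(Cc1cnnn1-c1ccc(Cl)cc1Cl)c1ccccc12` differs from compound 3 in a single place: 2,4-dichlorophenyl in place of 4-methoxyphenyl on an aromatic nitrogen. Among the compounds with values here, no measured step covers this exchange, and the only step present in the set is unreadable, so nothing shows how large a change such a swap can bring. Since every measured compound sits at the limit, compound 4 is expected to stay there as well, with an expected step that the limit leaves unreadable from compound 3 to compound 4. Compound 4 is therefore estimated at 70000 nM, with a plausible range from 20000 nM to 250000 nM, and the assay will most probably again report only a limit.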

Compound 4, half-maximal inhibitory concentration: > 50000 nM
Compound 4 gave a limit, no number; the forecaster's own chance of this, stated with the estimate: 85%; the middle value does not contradict the limit.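

In this assay compound 3 and compound 4 both stop at a limit of the assay rather than a measured number, so the swap between them cannot be read as a step. The whole set sits at one reading: the limit of > 50000 nM in this assay, at which 4 of the 4 values shown sit. These compounds leave open whether any change to the shared core would bring a measurable value.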